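This account rests on a few compounds, and the source may have more. Where it says the series, first, only, none or still open, it means among the compounds named here.

Working notes on the series. Compound 1 `COC(=[Se])Nc1ccc2c(C)cc(=O)oc2c1` is reported in a functional assay on T47D cells (Homo sapiens) for inhibition, read by sulforhodamine B assay, with a stated time of 48 h (a higher number here means a weaker inhibitor of growth, a lower number a stronger inhibitor of growth), only as a limit, > 100000 nM. Compound 2 `CCCOC(=[Se])Nc1ccc2c(C)cc(=O)oc2c1` gives 41000 nM in this assay. Compound 3 `Cc1cc(=O)oc2cc(NC(=[Se])Nc3ccccc3)ccc12` gives 24000 nM, and a 1.7-fold lower number from compound 2 to compound 3 (0.23 log units; within the scatter) lies within the scatter, so compound 3 stands level with compound 2 and the two cannot be ranked.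

Compound 4 `Cc1cc(=O)oc2cc(NC(=[Se])Nc3ccc(C(F)(F)F)cc3)ccc12` has trifluoromethyl in place of hydrogen on an aromatic carbon, para to a large group (trifluoromethyl in place of hydrogen on an aromatic carbon). Among the compounds with values here, no measured step makes a change on this ring, so the evidence is indirect. The nearest guides are an at least 2.4-fold lower number from compound 1 to compound 2 (0.38 log units; beyond the scatter) and an at least 4.1-fold lower number from compound 1 to compound 3 (0.61 log units; beyond the scatter), both beyond the scatter, with added heavy atoms going along with lower numbers. As far as these compounds go, both start from the limit (the limit of > 100000 nM in this assay, at which 1 of the 3 values shown sits), so their true sizes remain open. Against this pattern, a 1.7-fold lower number from compound 2 to compound 3 (0.23 log units; within the scatter) shows no change beyond the scatter.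

A modest shift towards a lower number is therefore expected in this assay, though a step within the scatter would not surprise. The expected change is a 1.8-fold lower number from compound 3 to compound 4 (0.27 log units; within the scatter). For compound 4 the estimated value is 13000 nM, with an expected range of 4000 nM to 40000 nM.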

Compound 4, concentration for 50% growth inhibition: 8700 nM
The estimate for compound 4 lay 1.5-fold (0.17 log units) above the measured number; low and high end bracket the measured number.
By their numbers in this assay, from the lowest: compound 4; then compounds 3 and 2 (each within the scatter of the next). At a limit, above all of these: compound 1.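

Within the data shown here, compound 4 gives the first measured change on the six-membered aromatic ring of carbon only: trifluoromethyl in place of hydrogen, para to a large group, gives a 2.8-fold lower number from compound 3 to compound 4 (0.44 log units; beyond the scatter) in this assay, whereas the earlier step between two numbers, a 1.7-fold lower number from compound 2 to compound 3 (0.23 log units; within the scatter), did not leave the scatter. This therefore shows that a single substitution at this position can shift the number beyond the scatter, and both ends of the step are true numbers, so its size can be read directly. Compound 1, by contrast, is known only as a limit, and the steps that start from it have no fixed size: the limit of > 100000 nM in this assay, at which 1 of the 4 values shown sits. Nothing among the measurements gives a cause for the new step.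

As far as these compounds go, whether this shift belongs to trifluoromethyl in particular or would also follow from another group at the same position, such as fluorine, methoxy, an amine or a carboxylic acid, remains open. Also open, from the compounds shown here alone, is whether trifluoromethyl would give a similar step elsewhere on this ring, or on compounds that keep the propoxy group of compound 2 in place of the anilino group.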